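This account rests on a few compounds, and the source may have more. Where it says the series, first, only, none or still open, it means among the compounds named here.

Three compounds were examined in a functional assay on CCRF-CEM cells (Homo sapiens) for antiproliferative activity, read by MTT assay, with a stated time of 72 h; a higher number here means a weaker inhibitor, a lower number a stronger inhibitor. Compound 1 `CC(Br)C(=O)Nc1cccc(C(=O)NC(N)=O)c1` gives 1470 nM in this assay. Compound 2 `NC(=O)NC(=O)/C=C/c1cccc(NC(=O)CBr)c1` gives 1380 nM, and compound 3 `O=C(CBr)Nc1cccc(C(=O)NC(=O)Nc2ccccc2)c1` gives 5010 nM. Within this small set, compound 1 stands second highest of the three numbers; its number and that of compound 2 sit within the usual scatter of each other, so no order between them can be claimed, while compound 3 has a number beyond the scatter above compound 1.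

Compound 4 `CC(Br)C(=O)Nc1cccc(C(=O)NC(=O)Nc2ccccn2)c1` has not yet been measured in this assay. It differs from compound 1 in one place: pyridin-2-yl in place of hydrogen on an amide-type nitrogen. Among the measured compounds shown here, no directly measured pair in this set makes this exact change, so there is no step to lean on. For the measured compounds named here, what the numbers do show is that compound 3, the only compound here carrying an aromatic ring on that urea nitrogen, has the highest number of the three, above compound 1. On that basis the step from compound 1 to compound 4 is expected to go toward a higher number, likely beyond the scatter but of modest size, a 2.2-fold higher number from compound 1 to compound 4 (0.34 log units; beyond the scatter). Compound 4 is therefore estimated to give about 3200 nM in this assay, with a plausible range from 1200 nM to 8500 nM.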

Compound 4, half-maximal inhibitory concentration: 6230 nM
For compound 4 the middle estimate is 1.9-fold (0.29 log units) below the measured one; the measured number falls inside the stated range.
By their numbers in this assay, from the lowest: compounds 2 and 1 (each within the scatter of the next); then compounds 3 and 4 (each within the scatter of the next).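

Among the compounds shown here, compound 1 to compound 4 is the first pair here that isolates a single change on this urea nitrogen: in this assay, putting pyridin-2-yl in place of hydrogen on an amide-type nitrogen gives a 4.2-fold higher number from compound 1 to compound 4 (0.63 log units; beyond the scatter). The step lies beyond the usual scatter, so this position is not indifferent to what it carries, and this aromatic ring goes with a weaker result than the bare hydrogen. Nothing presented here accounts for the rise, so the step stands as an observation without an explanation.

A single step cannot show whether the rise belongs to pyridin-2-yl in particular or to any group placed on this nitrogen, so it would take a small methyl, a longer chain such as butyl or a pyridin-4-yl on the core of compound 1 to tell these apart. Also open, going by these compounds, is whether the same change would give a step of similar size on the core of compound 2, where an unsubstituted urea end also stands.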